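Lipophilicity of an aryl-piperazine swap in a pyridazinyl benzamide series

A few compounds are considered here, and "the series" means these few. Any claim that something is new, unique, unknown or untested is made for them only; others in the source may bear on it.

Compound 1 `O=C(Nc1ccnnc1)c1cc(N2CCNCC2)ccc1OCc1ccccc1`: 1.9
Compound 2 `O=C(Nc1ccnnc1)c1cc(N2CCC(O)CC2)ccc1OCc1ccccc1`: 3.2
Compound 3 `CN1CC2(CCN(c3ccc(OCc4ccccc4)c(C(=O)Nc4ccnnc4)c3)CC2)C1`: 2.2

In a physicochemical assay for lipophilicity, at pH 7.4 (on this read-out higher numbers stand for higher lipophilicity and lower numbers for lower lipophilicity), compound 3 stands second highest of the three, its nearest neighbour being compound 1 and its furthest compound 2. Compound 4 `CN1CCN(c2ccc(OCc3ccccc3)c(C(=O)Nc3ccnnc3)c2)CC1` differs from compound 3 in one place: a group of 7 heavy atoms (5 carbon, 2 nitrogen; one six-membered non-aromatic ring with 2 hetero atoms) in place of a group of 10 heavy atoms (8 carbon, 2 nitrogen; one four-membered non-aromatic ring with 1 hetero atom, one six-membered non-aromatic ring with 1 hetero atom), on an aromatic carbon. The step that bears most on this change is a number 0.30 log units higher from compound 1 to compound 3 (within the scatter), where the same group that now leaves entered in place of piperazin-1-yl; the larger step of a number 1.00 log units lower from compound 2 to compound 3 (beyond the scatter) shows what a different six-membered ring did at that position. Since the exchange of that group for a piperazine ring moved this assay only within the scatter, and the entering ring carries a methyl on its second nitrogen, compound 4 is expected to sit close to compound 3, with a small rise at most; the estimated step is a number 0.30 log units higher from compound 3 to compound 4 (within the scatter). Compound 4 is estimated at 2.5, within 1.9 to 3.1.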

Compound 4, distribution coefficient: 3
Compound 4: the middle estimate sits 0.50 log units below what was measured; the measured number falls inside the stated range.
By their numbers in this assay, from the lowest: compounds 1 and 3 (each within the scatter of the next); then compounds 4 and 2 (each within the scatter of the next).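

In this assay, among these compounds, a single methyl on the ring amine nitrogen makes a large difference (a number 1.10 log units higher from compound 1 to compound 4 (beyond the scatter)), which the earlier compounds did not show at this position. The 4-methylpiperazin-1-yl group also separates clearly from the larger group of compound 3 (a number 0.80 log units higher from compound 3 to compound 4 (beyond the scatter)), though the two have equal counts of hydrogen-bond donors and acceptors, while it stays level with 4-hydroxypiperidin-1-yl (a number 0.20 log units lower from compound 2 to compound 4 (within the scatter)). Nothing measured here accounts for these steps. The compounds shown leave open whether a longer chain such as ethyl on that nitrogen would follow the methyl. They also leave open how an acetyl group there would compare.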